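The source may hold more compounds than are shown below. What is called first, only, known or untested is meant among the compounds shown, and "the series" means these compounds.

Of the compounds shown here, three have been tested in a functional assay on HCT-8 cells (Homo sapiens) for antiproliferative activity, read by MTT assay, with a stated time of 48 h (on this read-out lower numbers stand for stronger inhibition and higher numbers for weaker inhibition), and a fourth awaits its turn. Compound 1 `CCNCC(=O)Nc1cc(OC)ccc1C(=O)c1ccc2c(c1)C=CC(C)(C)O2` carries an ethylamino group on a saturated chain carbon bound to a carbonyl carbon; in this assay compound 1 gives 3990 nM. Compound 2 `COc1ccc(C(=O)c2ccc3c(c2)C=CC(C)(C)O3)c(NC(=O)CN(C)C)c1` keeps the same core and differs from compound 1 by a single change, (dimethylamino in place of ethylamino on a saturated chain carbon bound to a carbonyl carbon). In this assay compound 2 gives 2420 nM. That one change made the step of a 1.6-fold lower number from compound 1 to compound 2 (0.22 log units; within the scatter).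

Compound 3 `C=C(c1cc(OC)c(OC)c(OC)c1)c1ccc(OC)cc1NC(=O)CNCC` is built on a different core, and how its core differs from that of compound 1 is not broken down here. In this assay compound 3 gives 590 nM, the lowest of the three numbers; its gaps to compound 2 and to compound 1 both lie beyond the usual scatter of repeated measurements.

Compound 4 `C=C(c1cc(OC)c(OC)c(OC)c1)c1ccc(OC)cc1NC(=O)CN(C)C` is the one still to be measured. It differs from compound 3 by dimethylamino in place of ethylamino on a saturated chain carbon bound to a carbonyl carbon, the same change, at the same place, that turned compound 1 into compound 2. Because the earlier step of a 1.6-fold lower number from compound 1 to compound 2 (0.22 log units; within the scatter) stayed within the scatter, a step of about the same modest size is expected here, a 1.3-fold lower number from compound 3 to compound 4 (0.12 log units; within the scatter). The number expected for compound 4 in this assay is 450 nM, with a plausible range from 200 nM to 1000 nM. The measured value will show whether this holds.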

Compound 4, half-maximal inhibitory concentration: 340 nM
Compound 4: middle estimate off by 1.3-fold (0.12 log units), on the high side, and the stated range covers the measured number.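

Replacing ethylamino with dimethylamino on a saturated chain carbon bound to a carbonyl carbon gives, on the second core, a 1.7-fold lower number from compound 3 to compound 4 (0.24 log units; within the scatter) in this assay. Set beside the earlier step on the first core, the change looks the same on both: the same change on two cores in this assay, a 1.6-fold lower number (0.22 log units; within the scatter) from compound 1 to compound 2 and a 1.7-fold lower number (0.24 log units; within the scatter) from compound 3 to compound 4, 1.1-fold (0.02 log units) apart, within the scatter of two such steps. This shows that, for these two pairs of compounds, the change carried from one core to the other with a step of about the same size, but it does not show that the change has a real effect on either core, since each step on its own is no larger than the differences expected between repeated measurements, and two pairs cannot say what would happen on a third core.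

The compounds shown carry only ethylamino and dimethylamino at this place, which leaves open what a plain amino group, a diethylamino group or a carboxylic acid would do there on either core. Also open, going by these compounds, is whether a longer chain between the amine and the carbonyl would give steps that match across the two cores, as these do, or steps that differ.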